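The source may report more compounds than this note shows. Statements on the series, on what has been measured and on what is new or still open speak of the compounds shown alone.

Working notes on the series. Compound 1 `CC(C)(C)CNc1ncnc2c1ncn2C1O[C@H](CO)[C@@H](O)[C@H]1O` gives 17 nM in an assay on cell membranes for binding affinity to adenosine receptor A1 (Cavia porcellus), read by radioligand binding (a higher number here means a weaker inhibitor, a lower number a stronger inhibitor), and stands lowest of the two numbers measured. Compound 2 `CCCn1c(=O)c2nc(C(C)(O)CC)[nH]c2n(CCC)c1=O` gives 240 nM in this assay, a larger number than compound 1 shows, beyond the scatter. Compound 3 `CCCC(CCC)Nc1ncnc2c1ncn2C1O[C@H](CO)[C@@H](O)[C@H]1O` differs from compound 1 by 1-propylbutyl in place of neopentyl on a nitrogen on an aromatic ring. Within the data shown here, no measured pair shows this change, so the step is expected to be small, at most modestly toward a lower number and possibly none beyond the scatter. Compound 3 is estimated at 10 nM, within 3 nM to 40 nM, giving an expected step of a 1.7-fold lower number from compound 1 to compound 3 (0.23 log units; within the scatter).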

Compound 3, inhibition constant: 3.3 nM
The estimate for compound 3 lay 3.0-fold (0.48 log units) above the measured number, within the range that was stated.
By their numbers in this assay, from the lowest: compound 3; then compound 1; then compound 2.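

On the nitrogen on an aromatic ring, 1-propylbutyl in place of neopentyl gives the first step measured at this position in this assay, a 5.2-fold lower number from compound 1 to compound 3 (0.71 log units; beyond the scatter), beyond the scatter. The position therefore responds to the change of alkyl group, and the group with more carbon gives the lower number. Nothing measured bears on the reason for this step.

As far as these compounds go, with only these two groups, the separate roles of chain length and branching remain open. A cyclopentyl ring, a benzyl group or a chain ending in an amine on this nitrogen would test them.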